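Swapping the aryl arm on a nitrocatechol pyrazoline

The source may hold more compounds than are shown below. What is called first, only, known or untested is meant among the compounds shown, and "the series" means these compounds.

Measured compounds:
- compound 1, `CC(=O)N1N=C(c2cc(O)c(O)c([N+](=O)[O-])c2)CC1c1ccc(C#N)cc1`, 48 nM
- compound 2, `O=C(/C=C/c1ccco1)c1cc(O)c(O)c([N+](=O)[O-])c1`, 230 nM
- compound 3, `Cn1cc(/C=C/C(=O)c2cc(O)c(O)c([N+](=O)[O-])c2)cn1`, 290 nM

All three share the nitrocatechol core and were tested in an assay for inhibition of Catechol O-methyltransferase (Rattus norvegicus), read by fluorescence and spectrophotometry; on this read-out lower numbers stand for stronger inhibition and higher numbers for weaker inhibition. Compound 1 gives the lowest number of the three; compound 2 and compound 3 both sit clearly higher, well beyond the scatter, so compound 1 is the strongest inhibitor among the measured set.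

Compound 4, `CC(=O)N1N=C(c2cc(O)c(O)c([N+](=O)[O-])c2)CC1c1cccs1`, differs from compound 1 in one place: thiophen-2-yl in place of 4-cyanophenyl on a saturated ring carbon.

Within the data shown here, no measured step touches exactly this change. Among the measured compounds shown here, the only step available, a 1.3-fold higher number from compound 2 to compound 3 (0.10 log units; within the scatter), swaps one small aromatic ring for another on the chain of the enone compounds and stays within the scatter. That suggests such aryl exchanges on this core need not move the number much, but it comes from a different part of a different scaffold, so it is only a loose guide.

For compound 4 a small shift toward weaker inhibition in this assay is therefore expected, with the step of a 1.7-fold higher number from compound 1 to compound 4 (0.22 log units; within the scatter) likely staying near the scatter. The estimated value for compound 4 is 80 nM, with a range from 30 nM to 250 nM.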

Compound 4, half-maximal inhibitory concentration: 210 nM
Compound 4: middle estimate off by 2.6-fold (0.42 log units), on the low side; low and high end bracket the measured number.
By their numbers in this assay, from the lowest: compound 1; then compounds 4, 2 and 3 (each within the scatter of the next).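

At this position, on the saturated ring carbon of a five-membered non-aromatic ring with 2 nitrogen, the aryl arm clearly matters in this assay: thiophen-2-yl in place of 4-cyanophenyl gives a 4.4-fold higher number from compound 1 to compound 4 (0.64 log units; beyond the scatter). This is the first change shown at this carbon, and unlike the exchange of small rings on the chain of compound 2 and compound 3, it moves the number beyond the scatter. The swap alters several things at once, replacing a six-membered carbon ring that carries a nitrile with a smaller five-membered ring containing sulfur, and no measurement shown here explains the loss.

The compounds shown leave open whether the nitrile or the six-membered ring accounts for the lower number of compound 1, a question that a plain phenyl at this carbon could help to separate. They also leave open how the number would respond to an amine or a carboxylic acid on that aromatic ring in place of the nitrile.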